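The source may report more compounds than this note shows. Statements on the series, on what has been measured and on what is new or still open speak of the compounds shown alone.

Measured compounds:
compound 1, `C=CCc1cc(O)c(O)c(CN2CCC(CO)CC2)c1`, 4.7% in a functional assay on HepG2 cells (Homo sapiens) for inhibition, read by MTT assay, with a stated time of 72 h, tested at 30 uM; on this read-out higher numbers stand for more inhibition of growth at the one concentration tested and lower numbers for less inhibition of growth
compound 2, `C=CCc1ccc(OCc2cn(-c3ccccc3Cl)nn2)c(O)c1`, 2.5%
compound 3, `C=CCc1cc(O)c(O)c(CN2CCC(C)CC2)c1`, 57.6%

Compound 2 shows the lowest of the three numbers in this assay. Its nearest neighbour is compound 1, whose value lies within the scatter of it, so the two cannot be told apart; the furthest is compound 3, which stands well beyond the scatter.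

The unmeasured compound 4, `C=CCc1ccc(OCc2cn(-c3ccc(C#N)cc3)nn2)c(O)c1`, differs from compound 2 in one place: 4-cyanophenyl in place of 2-chlorophenyl on an aromatic nitrogen.

Going by the values given here, the only measured step, a number 52.9 percentage points higher from compound 1 to compound 3 (beyond the scatter), concerns a change on a saturated chain carbon of a different core and says nothing about the group on the aromatic nitrogen. Among the compounds with values here, no measured step bears on the change from compound 2 to compound 4, so on the data at hand no step beyond the scatter is expected in this assay; compound 2 sets the anchor.

For compound 4 the value in this assay is therefore estimated at 5%, in the range -6% to 20%. This estimate corresponds to an expected step of a number 2.5 percentage points higher from compound 2 to compound 4 (within the scatter).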

Compound 4, percent growth inhibition at one concentration: 1.5%
For compound 4 the middle estimate is 3.5 percentage points above the measured one; measured number inside the range.
By their numbers in this assay, from the lowest: compounds 4, 2 and 1 (each within the scatter of the next); then compound 3.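

In this assay, going by these compounds alone, 4-cyanophenyl in place of 2-chlorophenyl on the aromatic nitrogen gives a number 1 percentage points lower from compound 2 to compound 4 (within the scatter), the first step that can be read at this position. The exchange alters the aryl group by adding a triple bond outside aromatic rings and a hydrogen-bond acceptor, yet compound 2 and compound 4 cannot be told apart. Nothing available explains this result.

The compounds shown leave open whether a carboxylic acid or an amine in place of the nitrile, or a benzyl group in place of the aryl group on that nitrogen, would give a number beyond the scatter of compound 2. They also leave open whether a change elsewhere on this core, such as an amine in place of the free hydroxy, would do so.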